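The source may report more compounds than this note shows. Statements on the series, on what has been measured and on what is new or still open speak of the compounds shown alone.

In a functional assay on HL-60 cells (Homo sapiens) for inhibition, read by MTT assay, with a stated time of 48 h, tested at 10 uM (a higher number here means more inhibition of growth at the concentration tested, a lower number less inhibition of growth), measured so far:
- compound 1 `Cc1oc2c([C@H]3CCN(C)C[C@H]3O)c(O)cc(O)c2c(=O)c1C(O)c1cccc(Cl)c1`: 22%
- compound 2 `Cc1oc2c([C@H]3CCN(C)C[C@H]3O)c(O)cc(O)c2c(=O)c1C(O)c1ccccc1Br`: 52%
- compound 3 `Cc1oc2c([C@H]3CCN(C)C[C@H]3O)c(O)cc(O)c2c(=O)c1C(O)c1c(Cl)cccc1Cl`: 14%

Compound 3 cannot be separated from compound 1, as a number 8 percentage points lower from compound 1 to compound 3 (within the scatter) shows. It sits well short of compound 2, with a number 38 percentage points lower from compound 2 to compound 3 (beyond the scatter).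

The next comparison is compound 4 `Cc1oc2c([C@H]3CCN(C)C[C@H]3O)c(O)cc(O)c2c(=O)c1C(O)c1cc(F)cc(F)c1`, which carries 3,5-difluorophenyl in place of 2,6-dichlorophenyl on a saturated chain carbon bound to an aromatic carbon and an oxygen on a saturated carbon. The count of heavy atoms stays the same, and neither group adds hydrogen-bond donors or acceptors.

All three measured steps are swaps of the aryl group at this same place, so all three bear on it. Their sizes vary widely: a number 30 percentage points higher from compound 1 to compound 2 (beyond the scatter) is modest, the step from compound 2 to compound 3 is large, and the step from compound 1 to compound 3 stays within the scatter. Going by the values given here, no measured compound carries fluorine, so the direction is poorly fixed. Read in reverse, these steps show that leaving 2,6-dichlorophenyl has so far either changed nothing beyond the scatter or raised the number, so a slight lean upward seems reasonable.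

The expected change is a number 9 percentage points higher from compound 3 to compound 4 (within the scatter), with no step beyond the scatter anticipated. The estimate for compound 4 is 23%, with an expected range of 8% to 46%.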

Compound 4, percent growth inhibition at one concentration: 30%
Compound 4: middle estimate off by 7 percentage points, on the low side, and the stated range covers the measured number.
By their numbers in this assay, from the lowest: compounds 3, 1 and 4 (each within the scatter of the next, the first and the last beyond it); then compound 2.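

In this assay, 3,5-difluorophenyl gives the first step away from 2,6-dichlorophenyl at this place to clear the scatter with an entering group other than 2-bromophenyl (a number 16 percentage points higher from compound 3 to compound 4 (beyond the scatter)). The same group remains well short of 2-bromophenyl (a number 22 percentage points lower from compound 2 to compound 4 (beyond the scatter)) but cannot be separated from 3-chlorophenyl (a number 8 percentage points higher from compound 1 to compound 4 (within the scatter)), so among these four aryl groups only compound 2 stands apart from all the others, even though compound 3 and compound 4 also separate from each other. Nothing measured here accounts for these differences.

Still open, on these data alone, is whether the higher number of compound 2 follows the bromine or its placement on the ring, as the halogen and the substitution pattern change together in every step to that compound. Also open, as far as these compounds go, is how a phenyl ring carrying an amine or a carboxylic acid, or a pyridine ring in place of the phenyl ring, would read at this place.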